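The source may report more compounds than this note shows. Statements on the series, on what has been measured and on what is new or still open speak of the compounds shown alone.

Compounds measured so far:
Compound 1, `CCN1CCN(CC(=O)Nc2ccc(-c3nc(-c4ccccc4)c(-c4ccccc4)n3C)cc2)CC1`, gives 51.2% in a functional assay on HT-29 cells (Homo sapiens) for cytotoxicity, read by MTT assay, with a stated time of 24 h, tested at 80 ug/mL; a lower number here means a weaker effect, a higher number a stronger effect of the compound at the concentration tested.
Compound 2, `Cn1c(-c2ccc(NC(=O)CN3CCN(Cc4ccccc4)CC3)cc2)nc(-c2ccccc2)c1-c1ccccc1`, gives 54.5% in this assay.
Compound 3, `Cc1ccc(CN2CCN(CC(=O)Nc3ccc(-c4nc(-c5ccccc5)c(-c5ccccc5)n4C)cc3)CC2)cc1`, gives 54.2% in this assay.

Compound 3 stands second highest of the three numbers; its nearest neighbour is compound 2, with a number 0.3 percentage points lower from compound 2 to compound 3 (within the scatter), and its furthest is compound 1, with a number 3 percentage points higher from compound 1 to compound 3 (within the scatter). All three values therefore sit within the scatter of one another.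

Compound 4, `COc1ccc(CN2CCN(CC(=O)Nc3ccc(-c4nc(-c5ccccc5)c(-c5ccccc5)n4C)cc3)CC2)cc1`, has not yet been measured in this assay. It differs from compound 3 in one place: methoxy in place of methyl on an aromatic carbon.

The step that bears most directly on this change is the one that also altered an aromatic carbon in this part of the molecule, a number 0.3 percentage points lower from compound 2 to compound 3 (within the scatter). The two steps that exchanged the group on the saturated chain carbon bound to the ring amine nitrogen, a number 3.3 percentage points higher from compound 1 to compound 2 (within the scatter) and a number 3 percentage points higher from compound 1 to compound 3 (within the scatter), were likewise within the scatter. Among the measured compounds shown here, nothing among the measured compounds points to a shift in this assay beyond the scatter, so the expected step of a number 0.2 percentage points lower from compound 3 to compound 4 (within the scatter) is essentially none.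

Compound 4 is therefore estimated at 54%, with a range from 44% to 64%.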

Compound 4, a percentage reported as activity, at one concentration (the size of the read-out at that concentration, not a potency): 51.2%
Compound 4: the middle estimate sits 2.8 percentage points above what was measured; the measured number falls inside the stated range.
By their numbers in this assay, from the lowest: compounds 1, 4, 3 and 2 (each within the scatter of the next).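

In this assay, methoxy, which brings one hydrogen-bond acceptor, gives a number 3 percentage points lower from compound 3 to compound 4 (within the scatter) in place of methyl on the aromatic carbon para to a large group, and a number 3.3 percentage points lower from compound 2 to compound 4 (within the scatter) in place of hydrogen there. Among the compounds shown here, with 4-methoxyphenyl in place of methyl on the saturated chain carbon, the result is no change at the digits printed from compound 1 to compound 4 (within the scatter), so the first oxygen-bearing group at this position still produces no step beyond the scatter. No measurement shown here offers an explanation for this result.

From the compounds shown here alone, whether an amine, a carboxylic acid or a chlorine on this aromatic carbon would give a step beyond the scatter remains open. So does whether the same groups would read alike at another concentration, since each number describes the size of the read-out at a single concentration and is not a potency.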